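This account rests on a few compounds, and the source may have more. Where it says the series, first, only, none or still open, it means among the compounds named here.

In a functional assay on HCT-116 cells (Homo sapiens) for antiproliferative activity, read by CCK-8 assay, with a stated time of 72 h (on this read-out higher numbers stand for weaker inhibition and lower numbers for stronger inhibition), the measured compounds are:
compound 1 `Nc1ccccc1NC(=O)c1ccc(CSc2ccc(F)cc2)cc1` with 4010 nM
compound 2 `Nc1ccccc1NC(=O)c1ccc(CSc2ccc(Cl)cc2)cc1` with 3750 nM

Among the measured compounds shown here, with compound 1 as its only neighbour, compound 2 stands at 3750 nM on this scale, level with that neighbour within the scatter. Compound 3 `Cc1cc(C)cc(SCc2ccc(C(=O)Nc3ccccc3N)cc2)c1` has not yet been measured. It keeps the rest of compound 2 and differs in one place, with 3,5-dimethylphenyl in place of 4-chlorophenyl on a sulfur.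

For the measured compounds named here, only one measured step bears on this, and only loosely. Exchanging chloro for fluoro on an aromatic carbon gave a 1.1-fold lower number from compound 1 to compound 2 (0.03 log units; within the scatter) and stayed within the scatter. Going by the values given here, that step shows one small swap on this ring leaving the number in place, but no measured compound carries a methyl group, so the evidence is thin. No step beyond the scatter is therefore expected, in either direction, and the range must stay wide. The estimated step is a 1.0-fold higher number from compound 2 to compound 3 (0.01 log units; within the scatter) on this thin basis. The estimated value for compound 3 is 3800 nM with an expected range from 1700 nM to 8000 nM in repeated measurements.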

Compound 3, half-maximal inhibitory concentration: 2490 nM
Compound 3: the middle estimate sits 1.5-fold (0.18 log units) above what was measured; low and high end bracket the measured number.
By their numbers in this assay, from the lowest: compounds 3, 2 and 1 (each within the scatter of the next).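

In this assay the earlier pair only traded one halogen for another, whereas here the halogen leaves altogether and 3,5-dimethylphenyl enters on the sulfur, giving a 1.5-fold lower number from compound 2 to compound 3 (0.18 log units; within the scatter) and also a 1.6-fold lower number from compound 1 to compound 3 (0.21 log units; within the scatter), both within the scatter. Among these three compounds, then, the place on the sulfur accepts a ring with no halogen and with its substituents set differently, and no step goes beyond the scatter, so a change larger than a halogen swap has still not separated the compounds. Nothing measured alongside these numbers offers an explanation for this result.

As far as these compounds go, both 4-chlorophenyl and 3,5-dimethylphenyl are six-membered aromatic rings of carbon only, with no hydrogen-bond donor or acceptor and no net charge, so it stays open whether a ring carrying an amine or a carboxylic acid would move the number beyond the scatter. From the compounds shown here alone, it also stays open whether a pyridine ring, or a longer saturated chain on the sulfur in place of the ring, would do so.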